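This account rests on a few compounds, and the source may have more. Where it says the series, first, only, none or still open, it means among the compounds named here.

Measured so far, in a physicochemical assay for lipophilicity; a lower number here means a more polar compound, a higher number a more lipophilic compound:

Compound 1, `CCCOc1ccc2[nH]c(-c3ccccc3)c(C3=C(Br)C(=O)NC3=O)c2c1`, gives 3.16.
Compound 2, `CCCCCOc1ccc2[nH]c(-c3ccccc3)c(C3=C(Br)C(=O)NC3=O)c2c1`, gives 3.75.
Compound 3, `CCc1ccc2[nH]c(-c3ccccc3)c(C3=C(Br)C(=O)NC3=O)c2c1`, gives 3.15.

Compound 3 has the lowest number of the three, yet compound 1 sits so close that the two cannot be told apart, and only compound 2 stands clearly higher. The step to compound 4, `CCc1ccc2[nH]c(-c3cccc(OC)c3)c(C3=C(Br)C(=O)NC3=O)c2c1`, is methoxy in place of hydrogen on an aromatic carbon. Among the measured compounds shown here, no measured step adds a methoxy, so none bears on it directly. The nearest hint is the exchange of an alkoxy group for an alkyl group, a number 0.01 log units lower from compound 1 to compound 3 (within the scatter), which suggests that an oxygen-bearing group does not move this assay much, while a number 0.59 log units higher from compound 1 to compound 2 (beyond the scatter) shows that added chain carbons do. For compound 4 a step of a number 0.05 log units higher from compound 3 to compound 4 (within the scatter) is expected, within the scatter, so the estimate for compound 4 is 3.2, ranging from 2.9 to 3.5.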

Compound 4, partition coefficient: 3.35
Compound 4: the middle estimate sits 0.15 log units below what was measured, and the stated range covers the measured number.
By their numbers in this assay, from the lowest: compounds 3, 1 and 4 (each within the scatter of the next); then compound 2.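

The earlier compounds shown here differ only in the alkyl or alkoxy group at one place on the shared core, whereas phenyl to 3-methoxyphenyl is a change at a different place, and this assay reads a number 0.20 log units higher from compound 3 to compound 4 (within the scatter). At this aromatic carbon, then, methoxy in place of hydrogen gives a step that cannot be told apart from the spread of repeated measurements. Nothing available here explains the size of this step.

As far as these compounds go, whether an amine or a carboxylic acid on this same ring would give a step beyond the scatter remains open.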